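Three amides measured, a dichlorophenyl amide still to come

The compounds below may be only part of what the source reports. "The series", "measured", "known", "first", "only" and "open" are said of these compounds alone.

Measured so far:
- Compound 1 `CCc1ccc(C(=O)Nc2ccc3nc(N4CCN(CC)CC4)cc(C)c3c2)cc1`: in a functional assay on SK-BR-3 cells (Homo sapiens) for antiproliferative activity, read by MTT assay, with a stated time of 72 h (on this read-out lower numbers stand for stronger inhibition and higher numbers for weaker inhibition), compound 1 gives 9850 nM.
- Compound 2 `CCN1CCN(c2cc(C)c3cc(NC(=O)c4ccc(OC)cc4)ccc3n2)CC1`: in this assay compound 2 gives 9000 nM.
- Compound 3 `CCN1CCN(c2cc(C)c3cc(NC(=O)c4cccc(F)c4)ccc3n2)CC1`: in this assay compound 3 gives 24900 nM.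

Compound 3 stands at the highest number of the three, that is, the weakest inhibition, with a 2.5-fold higher number from compound 1 to compound 3 (0.40 log units; beyond the scatter) and a 2.8-fold higher number from compound 2 to compound 3 (0.44 log units; beyond the scatter), both beyond the scatter. Compounds 1 and 2 sit within the scatter of each other, as a 1.1-fold lower number from compound 1 to compound 2 (0.04 log units; within the scatter) shows.

Compound 4 `CCN1CCN(c2cc(C)c3cc(NC(=O)c4cc(Cl)cc(Cl)c4)ccc3n2)CC1` differs from compound 3 only at the amide: 3,5-dichlorophenyl in place of 3-fluorophenyl on a carbonyl carbon. For the measured compounds named here, no measured step exchanges one halogenated phenyl for another, so the two steps into compound 3 bear on this change only loosely: they show that the 3-fluorophenyl amide is the weakest of the three, and the new group keeps a halogen at the same kind of place while adding a second one. With so little to go on, compound 4 is expected to stay close to compound 3, with the step of a 1.4-fold lower number from compound 3 to compound 4 (0.14 log units; within the scatter) expected to remain within the scatter. Compound 4 is therefore estimated at 18000 nM, within a range from 6000 nM to 55000 nM.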

Compound 4, half-maximal inhibitory concentration: 2660 nM
Compound 4: middle estimate off by 6.8-fold (0.83 log units), on the high side, and the stated range ends above it.
By their numbers in this assay, from the lowest: compound 4; then compounds 2 and 1 (each within the scatter of the next); then compound 3.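

The group on the amide carbonyl matters more than the first three compounds suggested, since the change to 3,5-dichlorophenyl gives a 9.4-fold lower number from compound 3 to compound 4 (0.97 log units; beyond the scatter) in this assay, a larger step than any seen among those three. The gain also holds against the two non-halogenated amides, with a 3.4-fold lower number from compound 2 to compound 4 (0.53 log units; beyond the scatter) and a 3.7-fold lower number from compound 1 to compound 4 (0.57 log units; beyond the scatter), so a halogenated phenyl here is not tied to weak inhibition and compound 4 is the strongest of the four. Nothing measured here accounts for this gain.

Compound 4 differs from compound 3 in both the kind of halogen and the number of halogens, and these two changes cannot be separated from the compounds shown. Going by these compounds, a 3-chlorophenyl or a 3,5-difluorophenyl amide would pull them apart, and whether non-halogen groups such as 3,5-dimethylphenyl would do as well remains open.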